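Nitro for Cyano on Two Cores in Prostate Cancer Cells

This account rests on a few compounds, and the source may have more. Where it says the series, first, only, none or still open, it means among the compounds named here.

Compound 1, `CC(O)(CS(=O)(=O)c1cccc(S(F)(F)(F)(F)F)c1)C(=O)Nc1ccc(C#N)cc1C(F)(F)F`: 22100 nM
Compound 2, `CC(O)(CS(=O)(=O)c1cccc(S(F)(F)(F)(F)F)c1)C(=O)Nc1ccc([N+](=O)[O-])cc1C(F)(F)F`: 100000 nM
Compound 3, `CC1(C)C(=O)N(c2ccc(C#N)cc2C(F)(F)F)C(=S)N1c1ccc(S(F)(F)(F)(F)F)cc1`: 12700 nM

These three values come from a functional assay on DU-145 cells (Homo sapiens) for antiproliferative activity, read by propidium iodide staining, with a stated time of 96 h; a lower number here means a stronger inhibitor, a higher number a weaker inhibitor. Compound 1 and compound 2 share one core and differ in a single place: nitro in place of cyano on an aromatic carbon. That change gave a 4.5-fold higher number from compound 1 to compound 2 (0.66 log units; beyond the scatter). Compound 3 rests on a different core; how the two cores differ is not broken down here. Compound 4, `CC1(C)C(=O)N(c2ccc([N+](=O)[O-])cc2C(F)(F)F)C(=S)N1c1ccc(S(F)(F)(F)(F)F)cc1`, has not yet been measured in this assay. It stands to compound 3 exactly as compound 2 stands to compound 1, the same change in the same surroundings: nitro in place of cyano on an aromatic carbon. Within the data shown here, the one measured example of this change is a 4.5-fold higher number from compound 1 to compound 2 (0.66 log units; beyond the scatter), and no other example is available. On that basis a step of similar size is expected for compound 4, namely a 4.3-fold higher number from compound 3 to compound 4 (0.64 log units; beyond the scatter). Compound 4 is therefore estimated at 55000 nM, most likely between 20000 nM and 100000 nM.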

Compound 4, half-maximal inhibitory concentration: 100000 nM
For compound 4 the middle estimate is 1.8-fold (0.26 log units) below the measured one; the measured number falls inside the stated range.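

In this assay, nitro in place of cyano again gave a weaker inhibitor, with a 7.9-fold higher number from compound 3 to compound 4 (0.90 log units; beyond the scatter). Set beside the earlier example, the two steps cannot be told apart in size: the same change on two cores in this assay, a 4.5-fold higher number (0.66 log units; beyond the scatter) from compound 1 to compound 2 and a 7.9-fold higher number (0.90 log units; beyond the scatter) from compound 3 to compound 4, 1.7-fold (0.24 log units) apart, within the scatter of two such steps

On these two cores, then, the change carries over in direction and in roughly its size, but two examples in one cell line do not show that it would hold on a further core, nor do they explain the loss.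

The compounds shown leave open how other groups at this aromatic carbon would behave, such as an amine, a carboxylic acid or a chlorine atom. Whether any of them would give a lower number than cyano is also unknown.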